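Methoxy in place of bromo: a flat series so far

The source may hold more compounds than are shown below. What is called first, only, known or untested is meant among the compounds shown, and "the series" means these compounds.

In a functional assay on Lewis lung carcinoma cells for cytotoxicity against Lewis lung carcinoma cell line (Mus musculus), read by MTT assay, with a stated time of 72 h (a lower number here means a stronger inhibitor, a higher number a weaker inhibitor), three compounds have been measured. Compound 1 `O=C1/C(=C/c2cccc(O)c2)COC/C1=C\c1ccccc1F` gives 13800 nM, compound 2 `O=C1/C(=C/c2ccccc2F)COC/C1=C\c1ccccc1C(=O)O` gives 17200 nM, and compound 3 `O=C1/C(=C/c2ccccc2F)COC/C1=C\c1ccccc1Br` gives 13300 nM. Compound 3 therefore stands within the scatter of both others, with compound 1 the nearest and compound 2 the furthest on the numbers.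

The next structure is compound 4 `COc1ccccc1/C=C1\COC/C(=C\c2ccccc2F)C1=O`, which has methoxy in place of bromo on an aromatic carbon, ortho to a large group: methoxy in place of bromo on an aromatic carbon.

Within the data shown here, two measured steps bear on this change. The step of a 1.3-fold lower number from compound 2 to compound 3 (0.11 log units; within the scatter) puts bromo in place of carboxy on an aromatic carbon, and the step of a 1.0-fold lower number from compound 1 to compound 3 (0.02 log units; within the scatter) puts 2-bromophenyl in place of 3-hydroxyphenyl. Both lie within the scatter, so neither substituent exchange has yet separated two compounds in this assay. Among the measured compounds shown here, no methoxy compound has been measured, so the evidence is indirect.

The step of a 1.1-fold higher number from compound 3 to compound 4 (0.02 log units; within the scatter) is expected to stay within the scatter, with no direction favoured. The estimate for compound 4 is 14000 nM, with an expected range of 8000 nM to 24000 nM.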

Compound 4, half-maximal inhibitory concentration: 15400 nM
The estimate for compound 4 lay 1.1-fold (0.04 log units) below the measured number; low and high end bracket the measured number.
By their numbers in this assay, from the lowest: compounds 3, 1, 4 and 2 (each within the scatter of the next).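

In this assay, the first methoxy on this aromatic carbon, ortho to a large group, leaves the reading unresolved from bromo: a 1.2-fold higher number from compound 3 to compound 4 (0.06 log units; within the scatter). The exchange adds a heavy atom and a hydrogen-bond acceptor, yet methoxy is also not separated from carboxy, a 1.1-fold lower number from compound 2 to compound 4 (0.05 log units; within the scatter), or from the 3-hydroxyphenyl variant, a 1.1-fold higher number from compound 1 to compound 4 (0.05 log units; within the scatter), so bromo, carboxy and methoxy at this place, along with the 3-hydroxyphenyl replacement, all remain unseparated across these four compounds. No available evidence bears on this result.

From the compounds shown here alone, whether an amine or a longer chain such as ethoxy on this same aromatic carbon would give a step beyond the scatter remains open, since every change so far stays within it. Going by these compounds, all four compounds also keep the shared core and a fluoro-bearing phenyl group, so it remains open whether replacing that fluoro with an amine or a carboxylic acid would separate any compound from the rest.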